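This account rests on a few compounds, and the source may have more. Where it says the series, first, only, none or still open, it means among the compounds named here.

Three compounds share one core and differ only in a group on one phenyl ring. Compound 1 `Cc1nnc(SCC(=O)N/N=c2/scc(-c3ccccc3)n2-c2ccccc2)s1` gives 63.9% in a functional assay on C6 cells (Rattus norvegicus) for cytotoxicity, read by MTT assay, with a stated time of 24 h, tested at 50 ug/mL; on this read-out lower numbers stand for a stronger effect and higher numbers for a weaker effect at the one concentration tested. Compound 2 `Cc1nnc(SCC(=O)N/N=c2/scc(-c3ccc(F)cc3)n2-c2ccccc2)s1` gives 37.4%, and compound 3 `Cc1nnc(SCC(=O)N/N=c2/scc(-c3ccc(Cl)cc3)n2-c2ccccc2)s1` gives 37.9%. Compound 3 thus stands second highest of the three numbers: its number lies within the scatter of compound 2, while the step of a number 26 percentage points lower from compound 1 to compound 3 (beyond the scatter) is beyond it, and the step of a number 26.5 percentage points lower from compound 1 to compound 2 (beyond the scatter) points the same way. Compound 4 `COc1ccc(-c2cs/c(=N/NC(=O)CSc3nnc(C)s3)n2-c2ccccc2)cc1` differs from compound 3 by methoxy in place of chloro on an aromatic carbon. For the measured compounds named here, no measured step involves a methoxy group, so the fluoro and chloro steps are the only guide, and the step of a number 0.5 percentage points higher from compound 2 to compound 3 (within the scatter) shows those two alike. The expected step for compound 4 is a number 9.1 percentage points higher from compound 3 to compound 4 (within the scatter), a modest move back. Compound 4 is estimated at 47%, within 28% to 66%.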

Compound 4, a percentage reported as activity, at one concentration (the size of the read-out at that concentration, not a potency): 31.5%
Compound 4: the middle estimate sits 15.5 percentage points above what was measured, and the stated range covers the measured number.
By their numbers in this assay, from the lowest: compounds 4, 2 and 3 (each within the scatter of the next); then compound 1.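

Methoxy at this place reads like the two halogens: a number 6.4 percentage points lower from compound 3 to compound 4 (within the scatter) and a number 5.9 percentage points lower from compound 2 to compound 4 (within the scatter) both stay within the scatter, while a number 32.4 percentage points lower from compound 1 to compound 4 (beyond the scatter) lies beyond it. So swapping chloro for methoxy, which adds a heavy atom and a hydrogen-bond acceptor, leaves the number in the same range, and all three groups stand apart from hydrogen. Nothing available here explains this result.

From the compounds shown here alone, whether a hydroxyl, an amine or a longer chain such as ethoxy on this carbon would also fit that range remains open.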